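A few compounds are considered here, and "the series" means these few. Any claim that something is new, unique, unknown or untested is made for them only; others in the source may bear on it.

Two compounds of the series carry measured numbers. Compound 1 `CCn1c(C(=O)NCCN)ccc1C(CC)(CC)c1ccc(OCC(=O)C(C)(C)C)c(C)c1` in an assay on isolated protein for binding affinity to vitamin D3 receptor (Homo sapiens), with a stated time of 4 h (a higher number here means a weaker inhibitor, a lower number a stronger inhibitor), gives 1010 nM. Compound 2 `CCn1c(C(=O)NCCCN(C)C)ccc1C(CC)(CC)c1ccc(OCC(O)C(C)(C)C)c(C)c1` in this assay gives 197 nM, the lower of the two numbers, and the difference from compound 1 lies beyond the usual scatter. Compound 3 `CCn1c(C(=O)NCC(OC)OC)ccc1C(CC)(CC)c1ccc(OCC(O)C(C)(C)C)c(C)c1` differs from compound 2 by dimethoxymethyl in place of 2-(dimethylamino)ethyl on a saturated chain carbon bound to an amide-type nitrogen. For the measured compounds named here, no measured pair covers this change, so the two known values alone guide the expectation. A modest step toward a higher number is expected, a 2.0-fold higher number from compound 2 to compound 3 (0.31 log units; beyond the scatter). Compound 3 is expected to give 400 nM in this assay, within 150 nM to 1200 nM.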

Compound 3, half-maximal inhibitory concentration: 5240 nM
Compound 3: the middle estimate sits 13-fold (1.12 log units) below what was measured; measured number above the stated range.
By their numbers in this assay, from the lowest: compound 2; then compound 1; then compound 3.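

In this assay, the amide side chain proves highly sensitive to this change: dimethoxymethyl in place of 2-(dimethylamino)ethyl on a saturated chain carbon bound to an amide-type nitrogen gives a 27-fold higher number from compound 2 to compound 3 (1.42 log units; beyond the scatter). Both groups hold 5 heavy atoms, so this large step occurs without a change in heavy-atom count, as nitrogen gives way to two oxygens. From the compounds shown here alone, whether a carboxylic acid or a 4-(dimethylamino)butyl chain in this place would fall nearer compound 2 or compound 3 remains open, and no measurement available here bears on the origin of the step.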